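Lengthening the Methyl on the Sulfonamide Nitrogen Aryl Group

A few compounds are considered here, and "the series" means these few. Any claim that something is new, unique, unknown or untested is made for them only; others in the source may bear on it.

Of the compounds shown here, three sharing one core have been measured. Compound 1 `O=C(/C=C/c1cccnc1)NCCCc1ccc(S(=O)(=O)Nc2ccccc2)cc1` has the shortest linking chain, and in an assay on isolated protein for inhibition of Nicotinamide phosphoribosyltransferase (Homo sapiens), read by WST assay, with stated times of 60 min, 5 min and 30 min, in the presence of a further agent that is not named here (a higher number here means a weaker inhibitor, a lower number a stronger inhibitor), compound 1 gives 5920 nM. Compound 2 `O=C(/C=C/c1cccnc1)NCCCCCc1ccc(S(=O)(=O)Nc2ccccc2)cc1` has a longer chain, and in this assay compound 2 gives 28.4 nM. Compound 3 `Cc1ccc(NS(=O)(=O)c2cccc(CCCCCCNC(=O)/C=C/c3cccnc3)c2)cc1` has a longer chain still, together with a 4-methylphenyl group on the sulfonamide, and in this assay compound 3 gives 9.78 nM. Compound 3 therefore has the lowest number of the three: its gap to compound 2 is beyond the usual scatter, and its gap to compound 1 is far wider, so among these three it is the strongest inhibitor.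

Compound 4 `CCc1ccc(NS(=O)(=O)c2cccc(CCCCCCNC(=O)/C=C/c3cccnc3)c2)cc1` differs from compound 3 in one place: methyl in place of hydrogen on a saturated chain carbon bound to an aromatic carbon. Going by the values given here, no measured pair in this set shows the effect of such a change, so there is no step to lean on. The difference is small, and the expected step from compound 3 to compound 4 is a 1.0-fold higher number from compound 3 to compound 4 (0.01 log units; within the scatter), which is not beyond the scatter in either direction. Compound 4 is therefore estimated at 10 nM in this assay, with a range from 4 nM to 25 nM.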

Compound 4, half-maximal inhibitory concentration: 31.5 nM
Beside the measured number, compound 4's estimate is 3.2-fold (0.50 log units) below it; the measured number lies above the stated range.
By their numbers in this assay, from the lowest: compound 3; then compounds 2 and 4 (each within the scatter of the next); then compound 1.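

Changing 4-methylphenyl to 4-ethylphenyl in this assay gives a 3.2-fold higher number from compound 3 to compound 4 (0.51 log units; beyond the scatter) and so shows that this position responds to a single added carbon: methyl in place of hydrogen on a saturated chain carbon bound to an aromatic carbon weakens inhibition modestly, but by more than repeated measurements would scatter. Going by these compounds alone, the earlier compounds could not show this, as no pair among them formed a step that differed in one place, and this is therefore the only direct reading of a change at this end of the molecule. The measurements offer nothing that explains why the extra carbon raises the number.

From the compounds shown here alone, a single step gives a direction only for the move from methyl to ethyl, so it remains open whether a propyl or tert-butyl group in the same place would raise the number further or whether the effect would level off. Going by these compounds, it is also open whether the result depends on carbon chains alone, since a methoxy group or a chlorine atom there could give quite a different number.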